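Aryl to Benzyl on the Ring Nitrogen of Compound 1

The source may hold more compounds than are shown below. What is called first, only, known or untested is meant among the compounds shown, and "the series" means these compounds.

Compound 1, `Cc1ccc(-n2cc(CSC(=S)N3CCN(C(=O)OC(C)(C)C)CC3)nn2)cc1`, is measured in a functional assay on PC-3 cells (Homo sapiens) for inhibition, read by MTT assay, with a stated time of 72 h; a lower number here means a stronger inhibitor, a higher number a weaker inhibitor. In this assay compound 1 gives > 128000 nM, which is a limit rather than a number. Two related compounds carry a benzyl group on the same ring nitrogen: compound 2, `COc1cc(Cn2cc(CSC(=S)N3CCN(C(=O)OCc4ccccc4)CC3)nn2)cc(OC)c1OC`, and compound 3, `O=C(OCc1ccccc1)N1CCN(C(=S)SCc2cn(Cc3ccccc3F)nn2)CC1`. In this assay compound 2 gives > 128000 nM, again a limit. In this assay compound 3 gives 68300 nM. Within the data shown here, the only measured step, an at least 1.8-fold lower number from compound 2 to compound 3 (0.27 log units; that floor lies within the scatter), swaps one aryl group for another on that benzyl carbon, so it does not test the move from aryl to benzyl itself. Compound 4, `Cc1ccc(Cn2cc(CSC(=S)N3CCN(C(=O)OC(C)(C)C)CC3)nn2)cc1`, differs from compound 1 by 4-methylbenzyl in place of 4-methylphenyl on an aromatic nitrogen. Among the measured compounds shown here, with no step bearing directly on this change, and the limit of > 128000 nM in this assay, at which 2 of the 3 values shown sit, showing how weak the set is, compound 4 is expected to remain weak at 100000 nM (from 40000 nM to 250000 nM), an expected at least 1.2-fold lower number from compound 1 to compound 4 (0.10 log units; that floor lies within the scatter).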

Compound 4, half-maximal inhibitory concentration: 17300 nM
Compound 4: middle estimate off by 5.8-fold (0.76 log units), on the high side, and the stated range ends above it.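

Adding one carbon, so that 4-methylbenzyl replaces 4-methylphenyl on an aromatic nitrogen, gives an at least 7.3-fold lower number from compound 1 to compound 4 (0.86 log units; beyond the scatter). Among these compounds, this is the first step in the set to lie beyond the scatter, so the group on this nitrogen clearly matters in this assay. The true size of the step remains unknown, since the starting point is only a limit: the limit of > 128000 nM in this assay, at which 2 of the 4 values shown sit.

Going by these compounds, whether a longer chain, such as 2-phenylethyl, would lower the number further remains open. So does whether an amine on the aromatic ring would keep this gain.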